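A chlorine for five methyls on the aryl ring

The compounds below may be only part of what the source reports. "The series", "measured", "known", "first", "only" and "open" are said of these compounds alone.

In an ADME assay on Huh7.5.1 cells (Homo sapiens) for cytotoxicity, read by ATP content, with a stated time of 48 h (on this read-out lower numbers stand for higher toxicity in this test and higher numbers for lower toxicity in this test), compound 3 `Cc1oc(-c2c(C)c(C)c(C)c(C)c2C)nc1CN1CCC(C(=O)NCCCN2C[C@H](C)C[C@H](C)C2)CC1` gives 8180 nM, the highest of the three numbers shown. Compound 1 `Cc1ccc(C)c(-c2nc(CN3CCC(C(=O)NCCCN4C[C@H](C)C[C@H](C)C4)CC3)c(C)o2)c1` gives 4070 nM in this assay, a gap that lies within the scatter, and compound 2 `CC[C@@H]1C[C@H](CC)CN(CCCNC(=O)C2CCN(Cc3nc(-c4ccccc4C)oc3C)CC2)C1` gives 3470 nM, a gap that lies beyond it. Compound 4 `Cc1oc(-c2ccc(Cl)cc2)nc1CN1CCC(C(=O)NCCCN2C[C@H](C)C[C@H](C)C2)CC1` carries a (4-chlorophenyl in place of 2,3,4,5,6-pentamethylphenyl on an aromatic carbon). Within the data shown here, the only measured step touching the same aromatic carbon is a 2.0-fold higher number from compound 1 to compound 3 (0.30 log units; within the scatter), which stays within the scatter. Among the measured compounds shown here, no measured step leads to a halogen-bearing ring here, so only a small move is expected, in either direction. Compound 4 is therefore expected to give 5000 nM, between 2500 nM and 10000 nM. The expected step is a 1.6-fold lower number from compound 3 to compound 4 (0.21 log units; within the scatter).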

Compound 4, half-maximal cytotoxic concentration: 11500 nM
Beside the measured number, compound 4's estimate is 2.3-fold (0.36 log units) below it; measured number outside the range, above it.
By their numbers in this assay, from the lowest: compounds 2, 1, 3 and 4 (each within the scatter of the next, the first and the last beyond it).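

In this assay, the swap to 4-chlorophenyl gives a 1.4-fold higher number from compound 3 to compound 4 (0.15 log units; within the scatter), so the five methyls can give way to a single chlorine with no change beyond the scatter. Against the 2,5-dimethylphenyl ring, the same group gives a 2.8-fold higher number from compound 1 to compound 4 (0.45 log units; beyond the scatter), the only step shown at this aromatic carbon that lies beyond the scatter, and a modest one. No measurement here accounts for these numbers. Still open, going by these compounds, is how a 4-fluorophenyl, a 4-methoxyphenyl or a pyridyl ring would read at this carbon, and whether the chlorine's place on the ring matters.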